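A methyl added to the pyrimidine of a sulfonamide series

The source may hold more compounds than are shown below. What is called first, only, known or untested is meant among the compounds shown, and "the series" means these compounds.

Three compounds share one core and differ only in the group on the sulfonamide nitrogen. Compound 1 `CC(=O)NS(=O)(=O)c1ccc(N/C(S)=N\c2ccnc3cc(C(F)(F)F)ccc23)cc1` carries an acetyl group there, and in a functional assay on HT-1080 cells (Homo sapiens) for antiproliferative activity, read by sulforhodamine B assay, with a stated time of 48 h (on this read-out lower numbers stand for stronger inhibition and higher numbers for weaker inhibition), compound 1 gives 28300 nM. Compound 2 `Cc1cc(NS(=O)(=O)c2ccc(N/C(S)=N\c3ccnc4cc(C(F)(F)F)ccc34)cc2)on1` carries a 3-methyl-1,2-oxazol-5-yl group, and in this assay compound 2 gives 27300 nM. Compound 3 `Cc1ccnc(NS(=O)(=O)c2ccc(N/C(S)=N\c3ccnc4cc(C(F)(F)F)ccc34)cc2)n1` carries a 4-methylpyrimidin-2-yl group, and in this assay compound 3 gives 28700 nM. Compound 3 has the highest of the three numbers, yet its distance from the others is small: a 1.0-fold higher number from compound 1 to compound 3 (0.01 log units; within the scatter) and a 1.1-fold higher number from compound 2 to compound 3 (0.02 log units; within the scatter), and likewise a 1.0-fold lower number from compound 1 to compound 2 (0.02 log units; within the scatter). Nothing beyond the scatter separates these three.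

Compound 4 `Cc1cc(C)nc(NS(=O)(=O)c2ccc(N/C(S)=N\c3ccnc4cc(C(F)(F)F)ccc34)cc2)n1` has not been measured. It differs from compound 3 by methyl in place of hydrogen on an aromatic carbon. Within the data shown here, no measured step bears directly on this change; the three steps that exist all swap the whole group on the sulfonamide nitrogen, and all three stay within the scatter. Exchanging an entire group left this assay unmoved, so a single methyl on the pyrimidine is expected to leave it unmoved as well, with the step of a 1.0-fold lower number from compound 3 to compound 4 (0.01 log units; within the scatter) expected to fall within the scatter. Compound 4 is therefore estimated at 28000 nM, within a range of 14000 nM to 56000 nM.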

Compound 4, half-maximal inhibitory concentration: 29500 nM
For compound 4 the middle estimate is 1.1-fold (0.02 log units) below the measured one; low and high end bracket the measured number.
By their numbers in this assay, from the lowest: compounds 2, 1, 3 and 4 (each within the scatter of the next).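

Among these compounds, this is the first step that touches the pyrimidine itself rather than exchanging the whole group on the sulfonamide nitrogen: with methyl in place of hydrogen on an aromatic carbon next to the ring nitrogen, this assay shows a 1.0-fold higher number from compound 3 to compound 4 (0.01 log units; within the scatter). The new 4,6-dimethylpyrimidin-2-yl group also stays level with the other groups on that nitrogen, with a 1.1-fold higher number from compound 2 to compound 4 (0.03 log units; within the scatter) against the 3-methyl-1,2-oxazol-5-yl group and a 1.0-fold higher number from compound 1 to compound 4 (0.02 log units; within the scatter) against the acetyl group, so four different groups there now give values that cannot be told apart. Nothing shown here offers a reason for this flat picture.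

Going by these compounds, a methyl is a single carbon, and whether an amine, a carboxylic acid or a longer chain such as propyl on this same aromatic carbon would leave the number where it stands remains open. All four compounds also keep the shared core, so whether the level seen in this assay depends on that core, rather than on anything attached to the sulfonamide nitrogen, is a question these compounds cannot answer.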